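The source may hold more compounds than are shown below. What is called first, only, known or untested is meant among the compounds shown, and "the series" means these compounds.

Measured compounds:
Compound 1, `CC(C)COc1nc(C(C)(C)C)ccc1CNC(=O)C(C)c1ccc(NS(C)(=O)=O)c(F)c1`, gives 0.6 nM
Compound 2, `COCCCOc1nc(C(C)(C)C)ccc1CNC(=O)C(C)c1ccc(NS(C)(=O)=O)c(F)c1`, gives 5.6 nM
Compound 3, `CC(C(=O)NCc1ccc(C(C)(C)C)nc1SCCCN(C)C)c1ccc(NS(C)(=O)=O)c(F)c1`, gives 51.8 nM

In an assay on cells for antagonist activity at transient receptor potential cation channel subfamily V member 1 (Homo sapiens), read by FLIPR and calcium flux, with a stated time of 6 min (a higher number here means a weaker inhibitor, a lower number a stronger inhibitor), compound 3 stands highest of the three numbers, that is, it is the weakest inhibitor. The step of an 86-fold higher number from compound 1 to compound 3 (1.94 log units; beyond the scatter) is the largest change seen, and the step of a 9.3-fold higher number from compound 2 to compound 3 (0.97 log units; beyond the scatter) is smaller; the remaining step, a 9.3-fold higher number from compound 1 to compound 2 (0.97 log units; beyond the scatter), separates the two alkoxy compounds from each other.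

Compound 4, `CC(C(=O)NCc1ccc(C(C)(C)C)nc1SC1CCCC1)c1ccc(NS(C)(=O)=O)c(F)c1`, differs from compound 3 in one place: cyclopentyl in place of 3-(dimethylamino)propyl on a sulfur. Going by the values given here, no measured step tests this exact change. The two steps that end at compound 3 each exchanged an oxygen-linked chain for the dimethylamino-bearing sulfanyl chain and each raised the number, the larger rise coming from compound 1, whose isobutyl chain, like the cyclopentyl entering here, carries no hydrogen-bond acceptor. Whether the sulfur linker itself costs anything cannot be separated from the chain in these data, so the return toward compound 1 is uncertain in size.

Compound 4 is therefore expected to give a lower number than compound 3, a step of a 6.5-fold lower number from compound 3 to compound 4 (0.81 log units; beyond the scatter). The estimate for compound 4 is 8 nM, with a range from 2 nM to 40 nM.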

Compound 4, inhibition constant: 2.5 nM
Compound 4: middle estimate off by 3.2-fold (0.51 log units), on the high side; the range from low to high includes it.
By their numbers in this assay, from the lowest: compound 1; then compound 4; then compound 2; then compound 3.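

In this assay, going by these compounds alone, changing only the group on the sulfur, with cyclopentyl in place of 3-(dimethylamino)propyl, gives a 21-fold lower number from compound 3 to compound 4 (1.32 log units; beyond the scatter) and so shows that a compound with the sulfur link can reach a low number, which the earlier compounds could not show, since their only sulfur compound also carried the dimethylamino chain. Among the compounds compared here, the cyclopentylsulfanyl group is not simply better or worse than the oxygen-linked chains: replacing 3-methoxypropoxy gives a 2.2-fold lower number from compound 2 to compound 4 (0.35 log units; beyond the scatter) and is a gain, whereas replacing isobutoxy gives a 4.2-fold higher number from compound 1 to compound 4 (0.62 log units; beyond the scatter) and is a loss. Nothing measured here explains any of these steps.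

What the sulfur atom itself contributes remains open, as no pair shown keeps the chain fixed and exchanges only the linking atom, such as isobutylsulfanyl against isobutoxy or cyclopentylsulfanyl against cyclopentyloxy. Also open, as far as these compounds go, is how the number would respond to other groups on the sulfur, such as a cyclohexyl ring, a morpholine-bearing chain, a shorter dimethylaminoethyl chain or a carboxylic acid.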